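Removing the Distal Phenyl from Compound 1

The source may hold more compounds than are shown below. What is called first, only, known or untested is meant among the compounds shown, and "the series" means these compounds.

Compound 1 (`c1ccc(-c2ccc(NC3=NCCO3)cc2)cc1`) gives 8800 nM in a functional assay on M21 cells (Homo sapiens) for inhibition, read by sulforhodamine B assay, with a stated time of 48 h; a lower number here means a stronger inhibitor of growth, a higher number a weaker inhibitor of growth. That value lies within the scatter of compound 2 (`c1ccc(COc2ccc(NC3=NCCO3)cc2)cc1`) at 15900 nM, so these two cannot be ranked. Compound 3 (`c1ccc(COc2cccc(NC3=NCCO3)c2)cc1`), at 1500 nM, shows a lower number than compound 1, and that gap lies beyond the scatter. Compound 1 therefore sits at the weak end of this small set, level with compound 2.

Compound 4 (`Cc1ccc(NC2=NCCO2)cc1`) is the next to be read in this assay. It has methyl in place of phenyl on an aromatic carbon. Going by the values given here, every compound measured so far carries a phenyl group on its substituent, so the data hold no direct reading for a compound without one, and no measured pair differs in one place to size this change. With compound 1 at 8800 nM as the starting point, a move toward weaker growth inhibition is expected, modestly beyond the scatter, although no change cannot be ruled out. The expected step is a 3.4-fold higher number from compound 1 to compound 4 (0.53 log units; beyond the scatter). For compound 4 the estimated value is 30000 nM, with an expected range of 9000 nM to 100000 nM.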

Compound 4, concentration for 50% growth inhibition: 22000 nM
Compound 4: middle estimate off by 1.4-fold (0.13 log units), on the high side, within the range that was stated.
By their numbers in this assay, from the lowest: compound 3; then compounds 1, 2 and 4 (each within the scatter of the next, the first and the last beyond it).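

Going by these compounds alone, this is the first change that can be read at one place: in this assay, methyl in place of phenyl on an aromatic carbon gives a 2.5-fold higher number from compound 1 to compound 4 (0.40 log units; beyond the scatter). The step is modest but lies beyond the scatter, so at this carbon the phenyl of compound 1 has a measurable effect on the number, yet growth inhibition does not vanish without it, as compound 4 still gives 22000 nM in this small set. No measurement available here accounts for the step.

From the compounds shown here alone, whether the number follows the size of the group at this carbon remains open, since a single step from phenyl to methyl cannot show where an ethyl chain, a cyclohexyl ring or a simple hydrogen would fall. Also open, going by these compounds, is how a carboxylic acid or an amine on the same aromatic carbon would read, and whether the step from phenyl to methyl would keep its size on a different core.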